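Benzyl groups on the sulfur of the shared core

A few compounds are considered here, and "the series" means these few. Any claim that something is new, unique, unknown or untested is made for them only; others in the source may bear on it.

Among the compounds with values here, compound 1 `Sc1nnc(-c2ccc3c(c2)OCCO3)n1-c1ccccc1` is the only member of this small set with a number rather than a limit in a functional assay on BGC-823 cells (Homo sapiens) for antiproliferative activity, read by MTT assay, with a stated time of 24 h; a lower number here means a stronger inhibitor, a higher number a weaker inhibitor; compound 1 gives 47000 nM there. Compound 2 `Cc1ccccc1CSc1nnc(-c2ccc3c(c2)OCCO3)n1-c1ccccc1` carries a 2-methylbenzyl on the sulfur in place of hydrogen, and in this assay compound 2 reaches only the limit of > 100000 nM. Within the data shown here, the step of an at least 2.1-fold higher number from compound 1 to compound 2 (0.32 log units; beyond the scatter) is the one measured comparison that bears on the case at hand, and its open-ended size rests on (the limit of > 100000 nM in this assay, at which 1 of the 2 values shown sits).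

Compound 3 `Fc1ccc(CSc2nnc(-c3ccc4c(c3)OCCO4)n2-c2ccccc2)cc1` differs from compound 1 by 4-fluorobenzyl in place of hydrogen on a sulfur. Among the measured compounds shown here, a benzyl group on the sulfur has so far gone with a loss of activity, so the same direction is expected here; the size is uncertain, the one measured step being itself open-ended. Compound 3 is therefore expected to give about 100000 nM in this assay, within a range from 40000 nM to 300000 nM, and more likely than not to be reported as a limit. The expected step is a 2.1-fold higher number from compound 1 to compound 3 (0.33 log units; beyond the scatter).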

Compound 3, half-maximal inhibitory concentration: > 100000 nM
Compound 3 gave a limit, no number; the forecaster's own chance of this, stated with the estimate: 55%; the middle value sits exactly at the limit.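

The 4-fluorobenzyl in place of hydrogen on the sulfur gives an at least 2.1-fold higher number from compound 1 to compound 3 (0.32 log units; beyond the scatter) in this assay, so two different benzyl groups now go with a loss of activity on the shared core, and the loss no longer rests on the 2-methylbenzyl of compound 2 alone. This step is open-ended like the earlier one, so only a lower bound on the size of the loss is known for either group. The step from compound 2 to compound 3, 4-fluorophenyl in place of 2-methylphenyl, cannot be read, and the two benzyl groups cannot be ranked, because both values are limits: the limit of > 100000 nM in this assay, at which 2 of the 3 values shown sit.

Within the data shown here, compound 1, at 47000 nM, remains the only number in the set, and it remains open whether the loss follows from replacing the hydrogen on the sulfur as such or from the benzyl groups in particular. Also open, going by these compounds, is what a group of another kind on the sulfur would do, such as a methyl, or a longer chain ending in an amine or a carboxylic acid.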